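The compounds below may be only part of what the source reports. "The series", "measured", "known", "first", "only" and "open" are said of these compounds alone.

Among the measured compounds shown here, the account begins with compound 1 `CN1CCN(c2ccc(Nc3ncc4nc(Nc5ccc(F)cc5)n([C@H]5CCCN(C(=O)CO)C5)c4n3)cc2)CC1`, which in a functional assay on A-431 cells (Homo sapiens) for antiproliferative activity, read by MTT assay, with a stated time of 72 h (on this read-out higher numbers stand for weaker inhibition and lower numbers for stronger inhibition), gives 3000 nM, and this is the only number in the whole set: compound 2 `CN1CCN(c2ccc(Nc3ncc4nc(Nc5ccc(F)cc5)n([C@H]5CCCC(NC(=O)OC(C)(C)C)C5)c4n3)cc2)CC1` is recorded as "not determined" (no result reported) in this assay, and compound 3 `CN1CCN(c2ccc(Nc3ncc4nc(Nc5ccccc5)n([C@H]5CCN(S(C)(=O)=O)C5)c4n3)cc2)CC1` is recorded as "not determined" (no result reported) in this assay, so compound 1 stands neither above nor below anything else and is simply the single measured point. Compound 4 `CN1CCN(c2ccc(Nc3ncc4nc(Nc5ccc(F)cc5)n([C@H]5CCN(S(=O)(=O)C6CC6)C5)c4n3)cc2)CC1` has not yet been measured in this assay. It differs from compound 1 in one place: 1-(cyclopropylsulfonyl)pyrrolidin-3-yl in place of 1-((hydroxymethyl)carbonyl)piperidin-3-yl on an aromatic nitrogen. For the measured compounds named here, no pair of measured compounds with a single difference is available, so the size of such a step cannot be read from any other pair, and compound 3, though close in build, offers no number to compare against. A small move is expected for this step, within the usual scatter of repeated measurements or only slightly beyond it, and if anything toward stronger inhibition: a 1.5-fold lower number from compound 1 to compound 4 (0.18 log units; within the scatter). Compound 4 is accordingly estimated to give about 2000 nM in this assay, with a range from 500 nM to 8000 nM.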

Compound 4, half-maximal inhibitory concentration: 1670 nM
Beside the measured number, compound 4's estimate is 1.2-fold (0.08 log units) above it; low and high end bracket the measured number.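

In this assay, among the compounds shown here, the step from 1-((hydroxymethyl)carbonyl)piperidin-3-yl to 1-(cyclopropylsulfonyl)pyrrolidin-3-yl on an aromatic nitrogen gives a 1.8-fold lower number from compound 1 to compound 4 (0.25 log units; within the scatter) and is the first step that can be read at this position. It shows that the two compounds cannot be told apart in this read-out, even though the six-membered ring gives way to a five-membered ring with a cyclopropyl ring attached, the carbonyl gives way to a sulfonyl group, and the count of hydrogen-bond donors in the group goes from 1 to 0. No further measurement on these compounds bears on this result.

For the compounds shown here, compounds 2 and 3 carry no number, so no step involving them can be read, and this single step joins the ring swap and the swap on the ring nitrogen, leaving their separate contributions unresolved. Also open, on these data alone, is whether a free amine or a carboxylic acid on this ring, or a longer chain on the ring nitrogen, would move the number beyond the scatter.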